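Removing the Chloro Group from the Shared Core

A few compounds are considered here, and "the series" means these few. Any claim that something is new, unique, unknown or untested is made for them only; others in the source may bear on it.

Of the compounds shown here, three have been tested in a functional assay on LM7 cells (Homo sapiens) for antiproliferative activity, read by MTT assay, with a stated time of 72 h; a higher number here means a weaker inhibitor, a lower number a stronger inhibitor. Compound 1 `Cc1ccc2c(=O)c(CSC(=S)N(C(C)C)C(C)C)coc2c1` gives 6300 nM. Compound 2 `O=c1c(Cl)c(CSC(=S)N2CCOCC2)oc2ccccc12` gives 19200 nM, and compound 3 `O=c1c(Cl)c(CSC(=S)N2CCCC2)oc2ccccc12` gives 1900 nM. Compound 3 therefore stands lowest of the three numbers and is the strongest inhibitor of the set. Among the compounds with values here, the only step between two compounds differing in a single place, a 10-fold lower number from compound 2 to compound 3 (1.00 log units; beyond the scatter), concerns the group on the thiocarbonyl carbon rather than the ring.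

Compound 4 `O=c1cc(CSC(=S)N2CCCC2)oc2ccccc12` is compound 3 with one change: hydrogen in place of chloro on an aromatic carbon. Within the data shown here, no measured pair isolates this change, since compound 1 differs from compound 3 in several places at once and the step from compound 2 to compound 3 alters a different part of the molecule. Without a guiding comparison, the expectation in this assay is a small shift, probably within the scatter, with a slight lean toward a weaker inhibitor. Compound 4 is expected to give 3000 nM, within 900 nM to 12000 nM. This estimate corresponds to an expected step of a 1.6-fold higher number from compound 3 to compound 4 (0.20 log units; within the scatter).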

Compound 4, half-maximal inhibitory concentration: 40000 nM
Compound 4: middle estimate off by 13-fold (1.12 log units), on the low side; the whole stated range lies below it.
By their numbers in this assay, from the lowest: compound 3; then compound 1; then compound 2; then compound 4.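

In this assay, putting hydrogen in place of chloro on this aromatic carbon gives a 21-fold higher number from compound 3 to compound 4 (1.32 log units; beyond the scatter) and leaves the rest of the molecule untouched. Within the data shown here, the only earlier single-place step, a 10-fold lower number from compound 2 to compound 3 (1.00 log units; beyond the scatter), involved the group on the thiocarbonyl carbon, so this result is the first to show that the shared core also matters: with pyrrolidin-1-yl held constant, much of the activity of compound 3 depends on having chloro rather than hydrogen at this position. No available evidence explains why this change has such a large effect.

As far as these compounds go, it remains open whether another group on this carbon, such as bromo, methyl or methoxy, would serve as well as chloro. It is also unclear whether removing chloro would have a similar effect when morpholin-4-yl, as in compound 2, sits on the thiocarbonyl carbon.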